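The source may report more compounds than this note shows. Statements on the series, on what has been measured and on what is new or still open speak of the compounds shown alone.

In an ADME assay on LLC-MK2 cells (Macaca mulatta) for cytotoxicity, read by spectrophotometry and crystal violet staining, with a stated time of 4 days (a higher number here means that more compound is tolerated, a lower number that less compound is tolerated), compound 1 `CC(C)n1ncc2c(C(=O)Nc3ncccn3)cc(-c3cccs3)nc21` gives 75000 nM and compound 2 `CC(C)n1ncc2c(C(=O)Nc3ccccc3F)cc(-c3ccccn3)nc21` gives 100000 nM and these two numbers lie within the usual scatter of each other. Compound 3 `CC(C)n1ncc2c(C(=O)Nc3ccccc3F)cc(-c3cccnc3)nc21` is still unmeasured and differs from compound 2 by having pyridin-3-yl in place of pyridin-2-yl on an aromatic carbon. Going by the values given here, no measured pair shows what this swap does, so the estimated step of a 1.1-fold lower number from compound 2 to compound 3 (0.05 log units; within the scatter) is expected to stay within the scatter in this assay with no firm direction. For compound 3 the expected value is 90000 nM and the estimated range runs from 40000 nM to 170000 nM at this stage.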

Compound 3, half-maximal cytotoxic concentration: 50000 nM
For compound 3 the middle estimate is 1.8-fold (0.26 log units) above the measured one, and the stated range covers the measured number.
By their numbers in this assay, from the lowest: compounds 3, 1 and 2 (each within the scatter of the next).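

Going by these compounds alone, this is the first measured pair that isolates a change at this aromatic carbon: in this assay, pyridin-3-yl in place of pyridin-2-yl gives a 2.0-fold lower number from compound 2 to compound 3 (0.30 log units; within the scatter). The step lies within the usual scatter, so the two attachments of the pyridine ring cannot be told apart here. No measurement bears on why the numbers fall as they do.

Still open, going by these compounds, is whether pyridin-4-yl would also stay within the scatter. So is whether an amine or a carboxylic acid on that ring would move the number beyond it.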